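The compounds below may be only part of what the source reports. "The series", "measured", "known", "first", "only" and "open" are said of these compounds alone.

Within the data shown here, compound 3 `CC1=C(C(=O)CC(C)C)C(c2cccs2)NC(=O)N1` sits in the middle of the three compounds measured so far in an assay on membranes from CHO cells for displacement of a labelled ligand from adenosine receptor A1 (Homo sapiens), read by scintillation counting, with a stated time of 60 min, tested at 1 uM; a lower number here means less inhibition, a higher number more inhibition at the concentration tested (going by the name of the read-out). Compound 1 `CCCOC(=O)C1=C(C)NC(=O)NC1c1cccs1` gives 43%, compound 3 gives 19%, and compound 2 `CC1=C(C(=O)C2CC2)C(c2cccs2)NC(=O)N1` gives 1%. The step to compound 4 `CCNC(=O)C1=C(C)NC(=O)NC1c1cccs1` is ethylamino in place of isobutyl on a carbonyl carbon. The measured steps at the same carbonyl carbon are the two that reach compound 3: a number 24 percentage points lower from compound 1 to compound 3 (beyond the scatter) and a number 18 percentage points higher from compound 2 to compound 3 (beyond the scatter). Both show that swapping the group on this carbonyl moves the read-out by a modest to large amount, so a change beyond the scatter is expected here too, though no amide has been measured and the direction is uncertain. For compound 4 a modest rise is expected, a number 11 percentage points higher from compound 3 to compound 4 (beyond the scatter), giving 30% within 5% to 55%.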

Compound 4, a percentage reported as inhibition, at one concentration (the size of the read-out at that concentration, not a potency): 1%
The estimate for compound 4 lay 29 percentage points above the measured number, and the stated range ends above it.
By their numbers in this assay, from the lowest: compounds 2 and 4 (each within the scatter of the next); then compound 3; then compound 1.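

Placing ethylamino on this carbonyl carbon gives, in this assay, a number 18 percentage points lower from compound 3 to compound 4 (beyond the scatter) and a number 42 percentage points lower from compound 1 to compound 4 (beyond the scatter), with no change at the digits printed from compound 2 to compound 4 (within the scatter). So this first amide, whose ethylamino group brings a hydrogen-bond donor, reads the same as the cyclopropyl ketone within the scatter, and propoxy still gives the highest number of the four compounds. Nothing available explains the drop. Still open, as far as these compounds go, is whether dimethylamino, which lacks the amide hydrogen, or a longer chain on the amide nitrogen would restore the read-out. A butoxy group in place of propoxy is equally untested among these compounds.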